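From Compound 3 to Compound 4: A Ring Swap

A few compounds are considered here, and "the series" means these few. Any claim that something is new, unique, unknown or untested is made for them only; others in the source may bear on it.

Measured in a physicochemical assay for solubility, in phosphate buffer, at pH 7.4; on this read-out higher numbers stand for higher solubility and lower numbers for lower solubility:
- compound 1 `CC(=O)N[C@@H]1CCC[C@H](C(=O)Nc2cc(-c3cnc(C)n3C)c(Cl)cn2)C1`: > 1000000 nM (a limit of the assay, not a number)
- compound 2 `CC(=O)N[C@@H]1CCC[C@H](C(=O)Nc2cc(-c3cnn4c3CCCCC4)c(Cl)cn2)C1`: 104000 nM
- compound 3 `CC(=O)N[C@@H]1CCC[C@H](C(=O)Nc2cc(-c3cnn4c3NCCC4)c(Cl)cn2)C1`: 860000 nM

Of the two true numbers, compound 3 has the higher one, 860000 nM, and its gap to compound 2 lies beyond the usual scatter. The next candidate is compound 4 `CC(=O)N[C@@H]1CCC[C@H](C(=O)Nc2cc(-c3cnc4n3CC(C)(C)C4)c(Cl)cn2)C1`, whose change is a group of 10 heavy atoms (8 carbon, 2 nitrogen; one five-membered non-aromatic ring with 1 hetero atom, one five-membered aromatic ring with 2 hetero atoms) in place of a group of 9 heavy atoms (6 carbon, 3 nitrogen; one five-membered aromatic ring with 2 hetero atoms, one six-membered non-aromatic ring with 2 hetero atoms), on an aromatic carbon.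

Going by the values given here, two measured steps bear on this swap, as both change the group on the same aromatic carbon. One is an at least 9.6-fold lower number from compound 1 to compound 2 (0.98 log units; beyond the scatter), and the other is an 8.3-fold higher number from compound 2 to compound 3 (0.92 log units; beyond the scatter). In both, the group of 10 heavy atoms in compound 2 sits on the lower side. Compound 4 also carries a group of 10 heavy atoms, so a drop is expected. Its rings differ from those of compound 2, so the expected drop is smaller than those steps. The expected change is a 2.9-fold lower number from compound 3 to compound 4 (0.46 log units; beyond the scatter). The estimate for compound 4 is 300000 nM, with an expected range from 90000 nM to 1000000 nM.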

Compound 4, solubility: 280000 nM
Compound 4: the middle estimate sits 1.1-fold (0.03 log units) above what was measured, and the stated range covers the measured number.
By their numbers in this assay, from the lowest: compound 2; then compound 4; then compound 3. At a limit, above all of these: compound 1.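

In this assay the new group gives a 3.1-fold lower number from compound 3 to compound 4 (0.49 log units; beyond the scatter) and also a 2.7-fold higher number from compound 2 to compound 4 (0.43 log units; beyond the scatter) even though the groups of compound 2 and compound 4 have the same count of heavy atoms, so at this position that count alone does not fix the number. Compound 4 carries a five-membered non-aromatic ring where compound 2 has a seven-membered one, and it falls between compound 2 and compound 3. The remaining step, an at least 3.5-fold lower number from compound 1 to compound 4 (0.55 log units; beyond the scatter) starts from a limit and not a number, so it gives only a floor: the limit of > 1000000 nM in this assay, at which 1 of the 4 values shown sits.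

These few compounds cannot separate ring size from the other differences among the groups. Also open, as far as these compounds go, is what this assay would read for an amine or a carboxylic acid on the five-membered non-aromatic ring.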